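The source may hold more compounds than are shown below. What is called first, only, known or untested is meant among the compounds shown, and "the series" means these compounds.

Compound 1 `Cc1cccc(C)c1NC(=O)/C=C/C(=O)N1C/C(=C\c2ccc([N+](=O)[O-])cc2)C(=O)/C(=C/c2ccc([N+](=O)[O-])cc2)C1` and compound 2 `COc1ccc(NC(=O)/C=C/C(=O)N2C/C(=C\c3ccccc3)C(=O)/C(=C/c3ccccc3)C2)cc1` share the same core and differ at the amide end. In a functional assay on Molt4/C8 cells (Homo sapiens) for cytotoxicity (a lower number here means a stronger inhibitor, a higher number a weaker inhibitor), compound 1 gives 210 nM, the lower of the two values; in this assay compound 2 gives 1100 nM. Compound 3 `O=C(/C=C/C(=O)N1C/C(=C\c2ccc([N+](=O)[O-])cc2)C(=O)/C(=C/c2ccc([N+](=O)[O-])cc2)C1)Nc1ccc([N+](=O)[O-])cc1` has not been measured in this assay. It differs from compound 1 in one place: 4-nitrophenyl in place of 2,6-dimethylphenyl on an amide-type nitrogen. Among the compounds with values here, no measured pair shows this change, so its effect is unknown; a step of a 1.2-fold higher number from compound 1 to compound 3 (0.08 log units; within the scatter) is expected in this assay, not beyond the usual scatter in either direction. Compound 3 is therefore estimated at 250 nM, with a range from 80 nM to 800 nM.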

Compound 3, half-maximal inhibitory concentration: 430 nM
Beside the measured number, compound 3's estimate is 1.7-fold (0.24 log units) below it, and the stated range covers the measured number.
By their numbers in this assay, from the lowest: compound 1; then compound 3; then compound 2.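

In this assay, within the data shown here, the first measured change confined to the amide end, 4-nitrophenyl in place of 2,6-dimethylphenyl on the amide-type nitrogen, gives a 2.0-fold higher number from compound 1 to compound 3 (0.31 log units; beyond the scatter) with the rest of the molecule held constant. This modest step shows that the group on this nitrogen can alter the number, and that this replacement does not abolish activity. Nothing available here bears on why the number moves.

The compounds shown do not separate the loss of the two methyl groups from the gain of the nitro group. They also leave open how this assay would respond to an amine or a carboxylic acid on this phenyl ring.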